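This account rests on a few compounds, and the source may have more. Where it says the series, first, only, none or still open, it means among the compounds named here.

Working notes on the series. All compounds share one core and differ only in the aryl group on an oxygen on an aromatic ring. Compound 1 `Cc1nn(C)c(Oc2ccccc2F)c1/C=N\CCCCCCOc1cc2oc(=O)cc(C)c2cc1Cl` is tested in a functional assay on SMMC-7721 cells (Homo sapiens) for antiproliferative activity, read by MTT assay, with a stated time of 72 h; a lower number here means a stronger inhibitor, a higher number a weaker inhibitor; there compound 1 gives > 25000 nM, which is a limit of the assay rather than a number (the limit of > 25000 nM in this assay, at which 1 of the 3 values shown sits). Compound 2 `Cc1nn(C)c(Oc2cccc(F)c2)c1/C=N\CCCCCCOc1cc2oc(=O)cc(C)c2cc1Cl` gives 23600 nM, and compound 3 `Cc1nn(C)c(Oc2cccc(Cl)c2)c1/C=N\CCCCCCOc1cc2oc(=O)cc(C)c2cc1Cl` gives 5260 nM, the lowest of the two numbers. The step of a 4.5-fold lower number from compound 2 to compound 3 (0.65 log units; beyond the scatter) lies beyond the scatter, an at least 4.7-fold lower number from compound 1 to compound 3 (0.67 log units; beyond the scatter) is at least modest, and an at least 1.0-fold lower number from compound 1 to compound 2 (0.02 log units; that floor lies within the scatter) sits within the scatter.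

Compound 4 `Cc1nn(C)c(Oc2ccc(Br)cc2)c1/C=N\CCCCCCOc1cc2oc(=O)cc(C)c2cc1Cl` is not yet measured. Its difference from compound 3 is 4-bromophenyl in place of 3-chlorophenyl on an oxygen on an aromatic ring. Bearing on it are a 4.5-fold lower number from compound 2 to compound 3 (0.65 log units; beyond the scatter), a halogen exchange at an unchanged position, and an at least 4.7-fold lower number from compound 1 to compound 3 (0.67 log units; beyond the scatter), where halogen and position change together. For the measured compounds named here, no measured step moves a halogen within the phenyl ring alone, and no bromo compound has been measured, so the comparison is thin. For compound 4 the expected step is a 1.3-fold lower number from compound 3 to compound 4 (0.12 log units; within the scatter), within the scatter. Compound 4 is therefore expected to give 4000 nM, in the range 1200 nM to 15000 nM.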

Compound 4, half-maximal inhibitory concentration: 3090 nM
For compound 4 the middle estimate is 1.3-fold (0.11 log units) above the measured one, and the stated range covers the measured number.
By their numbers in this assay, from the lowest: compounds 4 and 3 (each within the scatter of the next); then compound 2. At a limit, above all of these: compound 1.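

In this assay, the 4-bromophenyl group on this oxygen stays level with the 3-chlorophenyl group, with a 1.7-fold lower number from compound 3 to compound 4 (0.23 log units; within the scatter), so exchanging the halogen and moving it together leaves the number unresolved from that of compound 3. Against the 3-fluorophenyl group, the same aryl group gives a 7.6-fold lower number from compound 2 to compound 4 (0.88 log units; beyond the scatter), so the heavier halogens shown both stand clear of that fluoro compound in this assay. With an at least 8.0-fold lower number from compound 1 to compound 4 (0.90 log units; beyond the scatter), the size of the step is only a floor, set by a limit of the assay: the limit of > 25000 nM in this assay, at which 1 of the 4 values shown sits.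

Whether the halogen or its ring position carries these differences remains open, since the compounds shown do not compare chloro and bromo at one position. Also open, from the compounds shown here alone, is whether a methoxy group or an amine on the phenyl ring would hold this level.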